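The source may hold more compounds than are shown below. What is called first, only, known or untested is meant among the compounds shown, and "the series" means these compounds.

Compound 1 `CC(=O)N[C@@H]1CCN(c2cc(C)nn3c(-c4ccccc4)c(C)nc23)C1`: in an ADME assay on microsomes from liver (Homo sapiens) for metabolic stability, read by LC-MS, with NADPH named in the record, with a stated time of 60 min, tested at 1 uM, in the absence of a further agent (on this read-out higher numbers stand for a more stable compound and lower numbers for a less stable compound), compound 1 gives > 95%, which is a limit of the assay.
Compound 2 `CC(=O)N[C@@H]1CCN(c2cc(C)nn3c(-c4ccc(C#N)cc4)c(C)nc23)C1`: in this assay compound 2 gives > 95%, which is a limit of the assay.
Compound 3 `COc1ccc(-c2c(C)nc3c(N4CC[C@@H](NC(=O)OCc5ccccc5)C4)cc(C)nn23)cc1OC`: in this assay compound 3 gives > 95%, which is a limit of the assay.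

Compound 3 therefore stands at the same limit as the other two measured compounds; every value shown sits there (the limit of > 95% in this assay, at which 3 of the 3 values shown sit). Within the data shown here, the only step between measured compounds, a step that the two limits leave unreadable from compound 1 to compound 2, is unreadable for the same reason, and it concerns a cyano in place of hydrogen on an aromatic carbon, not the change at hand.

Compound 4 `COc1ccc(-c2c(C)nc3c(N4CC[C@@H](O)C4)cc(C)nn23)cc1OC` differs from compound 3 by hydroxy in place of (benzyloxycarbonyl)amino on a saturated ring carbon. Among the measured compounds shown here, no measured step in this assay matches this change, so the size of the step from compound 3 cannot be read from the data. Given that all three measured compounds sit at the limit, compound 4 is estimated to give 90%, within 70% to 99%, which means an expected step of a number at least 5 percentage points lower from compound 3 to compound 4 (that floor lies within the scatter) from compound 3, most likely within the scatter.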

Compound 4, percent of the compound remaining: > 95%
Compound 4 ended at the assay's limit; the forecaster's own chance of this, stated with the estimate: 55%; middle value at least 5 percentage points from the limit.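

In this assay, among these compounds, compound 3 and compound 4 both stand at the limit, so no step between them can be read. The compounds shown leave open whether hydroxy and (benzyloxycarbonyl)amino on the saturated ring carbon differ at all on this read-out, because every value shown stands at that limit: the limit of > 95% in this assay, at which 4 of the 4 values shown sit.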